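Methyl on the Thiophene of Compound 1

The source may hold more compounds than are shown below. What is called first, only, known or untested is meant among the compounds shown, and "the series" means these compounds.

Measured compounds:
Compound 1, `COc1cccc(Nc2nccc(-c3cccs3)n2)c1`: 900 nM
Compound 2, `c1cc(Nc2nccc(-c3cccs3)n2)cc(-n2ccnc2)c1`: 300 nM

Compound 1 stands highest of the two numbers in a functional assay for inhibition, with Homo sapiens as the target; on this read-out higher numbers stand for weaker inhibition and lower numbers for stronger inhibition. Within the data shown here, its only neighbour, compound 2, lies a modest step away: a 3.0-fold lower number from compound 1 to compound 2 (0.48 log units; beyond the scatter). That step swaps the methoxy on the aromatic carbon for 1H-imidazol-1-yl and leaves the thiophen-2-yl ring untouched.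

Compound 3, `COc1cccc(Nc2nccc(-c3ccc(C)s3)n2)c1`, differs from compound 1 in one place: methyl in place of hydrogen on an aromatic carbon. Cut one bond further out, the change reads thiophen-2-yl to 5-methylthiophen-2-yl.

Among the measured compounds shown here, none of the measured steps touches this ring. The step from compound 1 to compound 2 alters the other end of the shared core, so it gives no guidance on a methyl entering the thiophene; the data hold nothing on this ring at all. For the measured compounds named here, with no bearing step, the expected step from compound 1 to compound 3 in this assay is none beyond the scatter, in either direction, and is estimated as a 1.1-fold lower number from compound 1 to compound 3 (0.05 log units; within the scatter).

Compound 3 is therefore expected to give about 800 nM in this assay, within a range from 300 nM to 2500 nM.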

Compound 3, half-maximal inhibitory concentration: 2300 nM
The estimate for compound 3 lay 2.9-fold (0.46 log units) below the measured number; measured number inside the range.
By their numbers in this assay, from the lowest: compound 2; then compound 1; then compound 3.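

The thiophene now has its first measured change: in this assay, methyl in place of hydrogen on the aromatic carbon next to the ring sulfur gives a 2.6-fold higher number from compound 1 to compound 3 (0.41 log units; beyond the scatter) and so moves the number beyond the scatter. This position therefore responds to the entry of a group of only 1 heavy atom, and it does so towards weaker inhibition, whereas the change at the other end of the shared core gave a 3.0-fold lower number from compound 1 to compound 2 (0.48 log units; beyond the scatter) and went towards stronger inhibition. Nothing available explains why 5-methylthiophen-2-yl gives weaker inhibition than thiophen-2-yl.

The compounds shown leave open whether the higher number belongs to methyl in particular or would also follow from another group on the same carbon, such as chlorine, an amine or a longer chain. They also leave open whether methyl on the other carbons of the thiophene would give a similar step, and whether the same change would carry over to compound 2, which bears 1H-imidazol-1-yl in place of methoxy.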